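Moving a Trifluoromethyl Group on a Benzyl Ether

The source may hold more compounds than are shown below. What is called first, only, known or untested is meant among the compounds shown, and "the series" means these compounds.

Three compounds built on a shared core have been measured in a functional assay on HCT-116 cells (Homo sapiens) for antiproliferative activity, read by MTT assay, with a stated time of 24 h; a lower number here means a stronger inhibitor, a higher number a weaker inhibitor:

Compound 1, `COc1ccc2c(=O)c(-c3cc(OC)c(OC)cc3OC)coc2c1`, gives 9170 nM.
Compound 2, `COc1cc(OC)c(-c2coc3cc(OCc4ccccc4C)ccc3c2=O)cc1OC`, gives 2900 nM.
Compound 3, `COc1cc(OC)c(-c2coc3cc(OCc4ccccc4C(F)(F)F)ccc3c2=O)cc1OC`, gives 4760 nM.

Compound 3 stands second highest of these three numbers; its nearest neighbour is compound 2, and its step to either of the other two lies within the scatter. The measured steps are a 3.2-fold lower number from compound 1 to compound 2 (0.50 log units; beyond the scatter), a 1.9-fold lower number from compound 1 to compound 3 (0.28 log units; within the scatter) and a 1.6-fold higher number from compound 2 to compound 3 (0.22 log units; within the scatter). Only the first of these lies beyond the scatter.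

Compound 4, `COc1cc(OC)c(-c2coc3cc(OCc4cccc(C(F)(F)F)c4)ccc3c2=O)cc1OC`, has not yet been measured. It differs from compound 3 in one place: 3-(trifluoromethyl)phenyl in place of 2-(trifluoromethyl)phenyl on a saturated chain carbon bound to an oxygen on an aromatic ring. Among the measured compounds shown here, no measured step involves moving a group around the aromatic ring of the benzyl; the steps of a 3.2-fold lower number from compound 1 to compound 2 (0.50 log units; beyond the scatter) and a 1.9-fold lower number from compound 1 to compound 3 (0.28 log units; within the scatter) concern attaching an aryl group to the saturated chain carbon, and a 1.6-fold higher number from compound 2 to compound 3 (0.22 log units; within the scatter) swaps methyl for trifluoromethyl. For the measured compounds named here, the data thus give no direct guide, and since the one swap on that ring stayed within the scatter, the expectation for compound 4 is no step beyond the scatter in this assay, a 1.2-fold lower number from compound 3 to compound 4 (0.08 log units; within the scatter). Compound 4 is estimated at 4000 nM, with a range from 1500 nM to 11000 nM.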

Compound 4, half-maximal inhibitory concentration: 3400 nM
The estimate for compound 4 lay 1.2-fold (0.07 log units) above the measured number, and the stated range covers the measured number.
By their numbers in this assay, from the lowest: compounds 2, 4, 3 and 1 (each within the scatter of the next, the first and the last beyond it).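

Among the compounds shown here, compound 4 gives the first reading in this set for moving the trifluoromethyl group around the aromatic ring of the benzyl, and in this assay the change from 2-(trifluoromethyl)benzyl to 3-(trifluoromethyl)benzyl gives a 1.4-fold lower number from compound 3 to compound 4 (0.15 log units; within the scatter) so this move shows no effect that can be told from the scatter. The step from the 2-methylphenyl group also stays within the scatter (in a 1.2-fold higher number from compound 2 to compound 4 (0.07 log units; within the scatter)) so the three aryl groups on the saturated chain carbon cannot be ranked against one another. Attaching 3-(trifluoromethyl)phenyl in place of hydrogen gives a 2.7-fold lower number from compound 1 to compound 4 (0.43 log units; beyond the scatter) which places compound 4 with compound 2 as a step beyond the scatter from compound 1, although compound 3 goes against this as a pattern for all aryl groups, and no supporting evidence bears on why these numbers fall as they do.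

The compounds shown leave open whether an amine or a carboxylic acid on that aromatic ring would give a step beyond the scatter from compound 2. They also leave open how a longer chain in place of the benzyl would read in this assay and whether any such change would hold in another cell line.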